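Aryl replacement on the amino-imidazole series: bromophenyl to thienyl

The source may report more compounds than this note shows. Statements on the series, on what has been measured and on what is new or still open speak of the compounds shown alone.

Measured compounds in a functional assay on HCT-116 cells (Homo sapiens) for cytotoxicity, read by MTT assay, with a stated time of 48 h; on this read-out higher numbers stand for weaker inhibition and lower numbers for stronger inhibition:
compound 1, `Cc1ccc(-c2cn(/N=C/c3cc4ccccc4nc3Cl)c(N)n2)cc1`, > 50000 nM
compound 2, `Nc1nc(-c2ccc(Cl)cc2)cn1/N=C/c1cc2ccccc2nc1Cl`, > 50000 nM
compound 3, `Nc1nc(-c2ccc(Br)cc2)cn1/N=C/c1cc2ccccc2nc1Cl`, > 50000 nM

Each of these three values is a limit of this assay and not a number. For compound 1 the value > 50000 nM is such a limit. For compound 2 the value > 50000 nM is such a limit. For compound 3 the value > 50000 nM is such a limit. Consequently the steps between them, a step that the two limits leave unreadable from compound 1 to compound 2, a step that the two limits leave unreadable from compound 1 to compound 3 and a step that the two limits leave unreadable from compound 2 to compound 3, cannot be read in size, and all three values sit at the same limit (the limit of > 50000 nM in this assay, at which 3 of the 3 values shown sit).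

Compound 3 therefore stands nowhere on a scale: it has only a limit, as do the two other compounds.

Compound 4, `Nc1nc(-c2cccs2)cn1/N=C/c1cc2ccccc2nc1Cl`, has not yet been measured. It differs from compound 3 by thiophen-2-yl in place of 4-bromophenyl on an aromatic carbon. Within the data shown here, no measured step bears on this change, since none of the measured steps could be read. Among the measured compounds shown here, the only evidence is the shared limit, and the change of aryl group is of a different kind from the substituent exchanges measured so far. The step that the limit leaves unreadable from compound 3 to compound 4 is therefore expected to be small and uncertain in direction. For compound 4 an estimate of 60000 nM, in the range 8000 nM to 300000 nM, is expected, with a high chance that this assay again reports only a limit.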

Compound 4, half-maximal inhibitory concentration: 7220 nM
Estimate against measurement, compound 4: 8.3-fold (0.92 log units) above; measured number outside the range, below it.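

In this assay, the aryl group on this aromatic carbon proves able to move the read-out: thiophen-2-yl gives an at least 6.9-fold lower number from compound 3 to compound 4 (0.84 log units; beyond the scatter), an at least 6.9-fold lower number from compound 2 to compound 4 (0.84 log units; beyond the scatter) and an at least 6.9-fold lower number from compound 1 to compound 4 (0.84 log units; beyond the scatter). The steps among compound 1, compound 2 and compound 3 cannot be read, so those compounds showed only a shared limit: the limit of > 50000 nM in this assay, at which 3 of the 4 values shown sit. Compound 4 alone has a number, and it comes from replacing the whole aryl ring, not from exchanging a substituent on the phenyl ring, with each step giving only a minimum size.

The compounds shown do not separate the five-membered ring from its sulfur atom, so which of the two goes with the step stays open. Furan-2-yl or unsubstituted phenyl on this carbon would bear on that, as would a methyl group or a carboxylic acid on the thiophene ring.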